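A few compounds are considered here, and "the series" means these few. Any claim that something is new, unique, unknown or untested is made for them only; others in the source may bear on it.

Series notes. Compound 1 `O=C1c2cc(F)c(Cl)cc2CCN1c1cccnc1` gives 3540 nM in an ADME assay on cells for inhibition of cytochrome P450 11B1, mitochondrial (Homo sapiens), read by HTRF; on this read-out higher numbers stand for weaker inhibition and lower numbers for stronger inhibition. Compound 2 `Cc1cc(Cl)ccc1C(=O)Nc1cccnc1` returns only a limit, > 3000 nM in this assay, not a number. Compound 3 `O=C(Nc1cccnc1)c1ccc(Cl)cc1` also returns a limit, > 3000 nM in this assay. The step that the two limits leave unreadable from compound 2 to compound 3, hydrogen in place of methyl on an aromatic carbon, stays unreadable because of the limit of > 3000 nM in this assay, at which 2 of the 3 values shown sit. Compound 4 `Cc1cc(Cl)ccc1C(=O)N(C)c1cccnc1` differs from compound 2 by methyl in place of hydrogen on an amide-type nitrogen. Among the compounds with values here, no measured step touches the amide-type nitrogen, so none of the measured steps bears on this change, and the only anchor is the limit of compound 2 in this assay. Compound 4 is therefore expected to remain weak, estimated at 6000 nM with a range of 2000 nM to 20000 nM. This estimate means an expected step that the limit leaves unreadable from compound 2 to compound 4, with a good chance that only a limit is reported again.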

Compound 4, half-maximal inhibitory concentration: > 3000 nM
Compound 4: no number, only a limit; the forecaster's own chance of this, stated with the estimate: 70%; the middle value does not contradict the limit.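

The step between compound 2 and compound 4 cannot be read, because both return only a limit: the limit of > 3000 nM in this assay, at which 3 of the 4 values shown sit. Going by these compounds, whether methyl in place of hydrogen on the amide-type nitrogen changes inhibition in this assay stays open.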